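The compounds below may be only part of what the source reports. "The series", "measured", "known", "first", "only" and "open" are said of these compounds alone.

Compound 1, `CNC(=O)c1sc(N2CC3CC2(CNC(=O)c2c[nH]c4ncc(C(F)(F)F)cc24)C3)nc1C(F)(F)F`, was measured in an assay on isolated protein for inhibition of tyrosine-protein kinase Mer (Homo sapiens), read by LC-MS, with stated times of 30 min and 120 min (a lower number here means a stronger inhibitor, a higher number a weaker inhibitor), and gave 63.1 nM. Going by the values given here, the only other compound measured alongside it is compound 2, `C[C@@H]1CN(c2cnc(Nc3cc(F)c(OCC4CC4)c(F)c3)nc2NC2CCOCC2)CCN1`, which in this assay gives 50.1 nM. The gap between compound 1 and compound 2 lies within the usual scatter of repeated measurements, so neither can be placed ahead of the other on these two numbers alone.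

The account now turns to compound 3, `CNC(=O)c1sc(N2CC3CC2(CNC(=O)c2c[nH]c4ncccc24)C3)nc1C(F)(F)F`, which has not yet been measured in this assay. It differs from compound 1 in one place: hydrogen in place of trifluoromethyl on an aromatic carbon. The trifluoromethyl group of compound 1 is removed and a hydrogen takes its place on the six-membered aromatic ring of the fused system.

Among the compounds with values here, no measured pair in this set shows the effect of such a change, so the expectation rests only on the single value of compound 1, 63.1 nM, and the size of the change. The step from compound 1 to compound 3 is expected to be a 2.5-fold higher number from compound 1 to compound 3 (0.40 log units; beyond the scatter), a modest weakening rather than none at all. Compound 3 is therefore estimated to give 160 nM in this assay, with a plausible range from 45 nM to 600 nM.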

Compound 3, half-maximal inhibitory concentration in the tyrosine-protein kinase Mer assay: 25.1 nM
Compound 3: middle estimate off by 6.4-fold (0.80 log units), on the high side; the whole stated range lies above it.
By their numbers in the tyrosine-protein kinase Mer assay, from the lowest: compounds 3, 2 and 1 (each within the scatter of the next, the first and the last beyond it).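

In the tyrosine-protein kinase Mer assay, hydrogen in place of trifluoromethyl on this aromatic carbon gives a 2.5-fold lower number from compound 1 to compound 3 (0.40 log units; beyond the scatter), so this change at this position goes with a stronger inhibitor, and the trifluoromethyl group is not required for inhibition of this order. In a physicochemical assay for lipophilicity, at pH 7.4 (a higher number here means a more lipophilic compound, a lower number a more polar compound), compound 1 gives 4.2 and compound 3 gives 3.1. Compound 3 is therefore the stronger inhibitor of the pair and also the less lipophilic one, a combination that could not be seen before this pair existed: the measured distribution coefficient of compound 1, 4.2, and of compound 3, 3.1, a number 1.10 log units lower (beyond the scatter)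

Going by these compounds alone, the data hold only a single pair with this change. They do not show what lies behind the lower number in the tyrosine-protein kinase Mer assay. From the compounds shown here alone, it also remains open how a chlorine atom, a methyl group, a nitrile or a methoxy group on the same aromatic carbon would fall in the tyrosine-protein kinase Mer assay and the physicochemical assay, and whether the lower number seen with hydrogen would hold for any of them.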